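Methylating the Sulfonamide Nitrogen of a Receptor Agonist

The source may report more compounds than this note shows. Statements on the series, on what has been measured and on what is new or still open speak of the compounds shown alone.

Compound 1, `Cc1cc2c(c(Oc3cccc(NS(=O)(=O)c4ccc(Cl)cc4)c3)n1)C(=O)N(C)C2=O`: 23 nM
Compound 2, `Cc1cc2c(c(Oc3cccc(NS(=O)(=O)c4ccc(Cl)cc4)c3)n1)C(=O)N(C(C)C)C2=O`: 13 nM

Both compounds were tested in a functional assay on HEK293 cells for agonist activity at Glucose-dependent insulinotropic receptor (Homo sapiens), read by cAMP accumulation, with a stated time of 30 min; on this read-out lower numbers stand for an effect already at smaller amounts and higher numbers for an effect only at larger amounts of compound. Compound 1 gives 23 nM there, and compound 2 gives 13 nM. Going by the values given here, compound 2 thus shows the lower of the two numbers, but the only measured step, a 1.8-fold lower number from compound 1 to compound 2 (0.25 log units; within the scatter), is within the scatter, so the two compounds cannot be ranked against each other on this evidence.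

Compound 3, `Cc1cc2c(c(Oc3cccc(N(C)S(=O)(=O)c4ccc(Cl)cc4)c3)n1)C(=O)N(C(C)C)C2=O`, is the next compound. It differs from compound 2 by methyl in place of hydrogen on a sulfonamide nitrogen. Among the compounds with values here, no measured step touches this part of the molecule: the one step seen so far concerns the amide-type nitrogen in the ring, not the sulfonamide nitrogen, so it gives no direct guide. The sulfonamide hydrogen is removed here, and the data contain nothing that shows whether it matters. An estimate for compound 3 must therefore be uncertain and is set close to compound 2 with a wide range: compound 3 is expected to give 40 nM, between 8 nM and 300 nM, which means an expected step of a 3.1-fold higher number from compound 2 to compound 3 (0.49 log units; beyond the scatter).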

Compound 3, half-maximal effective concentration: 11 nM
Compound 3: the middle estimate sits 3.6-fold (0.56 log units) above what was measured; measured number inside the range.
By their numbers in this assay, from the lowest: compounds 3, 2 and 1 (each within the scatter of the next, the first and the last beyond it).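

Methyl in place of hydrogen on the sulfonamide nitrogen gives a 1.2-fold lower number from compound 2 to compound 3 (0.07 log units; within the scatter) in this assay, so this change leaves the two compounds indistinguishable on this read-out. The earlier compounds shown here all carried the sulfonamide hydrogen and could not show whether agonist activity depends on it; compound 3 lacks that hydrogen and still gives a number in the same range as compound 2, so, with isopropyl on the amide-type nitrogen in the ring, the hydrogen is not required for activity here. Nothing in the data available here offers an explanation for this result.

What the compounds shown leave open is how much room this nitrogen allows, since methyl is the only replacement for the hydrogen here, and it remains unknown whether a longer chain such as n-butyl, or a chain ending in an amine or a carboxylic acid, would be accepted in its place. Also open, as far as these compounds go, is whether the same swap would give a similar result with methyl instead of isopropyl on the amide-type nitrogen in the ring, as in compound 1.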